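The compounds below may be only part of what the source reports. "The series", "measured", "known", "first", "only" and "open" are said of these compounds alone.

Compound 1 `CC(C)c1onc(-c2ccccc2Cl)c1COc1ccc(COc2ccc(CC(=O)O)cc2)cc1` is measured in an assay on HEK-293T cells for activation of Bile acid receptor (Homo sapiens), read by a luciferase reporter, with a stated time of 14 h (on this read-out higher numbers stand for an effect only at larger amounts of compound and lower numbers for an effect already at smaller amounts), where compound 1 gives 2500 nM. Its companion, compound 2 `CC(C)c1onc(-c2ccccc2Cl)c1COc1ccc(COc2ccc(OCC(=O)O)cc2)cc1`, keeps the whole of that structure except that it carries carboxymethoxy in place of carboxymethyl on an aromatic carbon; in this assay compound 2 gives 4700 nM. The step of a 1.9-fold higher number from compound 1 to compound 2 (0.27 log units; within the scatter) does not rise above the scatter of repeated measurements, so the two compounds cannot be told apart on this read-out. Going by the values given here, compound 1 holds the lower of the two numbers, and compound 2 is its only neighbour.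

Compound 3 `CC(C)c1onc(-c2ccccc2)c1COc1ccc(COc2ccc(CC(=O)O)cc2)cc1` is not yet measured. It differs from compound 1 by hydrogen in place of chloro on an aromatic carbon. Among the compounds with values here, no measured step touches this part of the molecule: the one step available concerns the acid end, far from the chlorophenyl, and it was itself within the scatter. There is therefore nothing in the measured pair to predict the size or direction of this change, and a step of at most modest size, in either direction, is the most that can be guessed. On that footing compound 3 is estimated at 5000 nM, within a range from 1500 nM to 16000 nM, which would mean an expected step of a 2.0-fold higher number from compound 1 to compound 3 (0.30 log units; within the scatter).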

Compound 3, half-maximal effective concentration: 11000 nM
The estimate for compound 3 lay 2.2-fold (0.34 log units) below the measured number; the measured number falls inside the stated range.
By their numbers in this assay, from the lowest: compounds 1 and 2 (each within the scatter of the next); then compound 3.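

Taking the chloro off the 2-chlorophenyl to leave plain phenyl gives a 4.4-fold higher number from compound 1 to compound 3 (0.64 log units; beyond the scatter) in this assay, the first step in this set that rises above the usual scatter of repeated measurements. The earlier swap at the acid end could not be told apart on this read-out, whereas this aromatic carbon, ortho to a large group, shows a readable difference from the exchange of a single chlorine atom for hydrogen, with compound 1 acting at smaller amounts than compound 3. The data show only the size and direction of this step and offer no measurement that would explain it.

Going by these compounds, it remains open whether chloro is special at this place or whether another group, such as fluoro, bromo, methyl or trifluoromethyl, would give a similar number or a lower one. On these data alone, it is also open whether the same hydrogen-for-chloro exchange would have a similar effect in compound 2, which carries carboxymethoxy instead of carboxymethyl at the acid end.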